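Trimming the Pyrimidine Methyl on a Steroidal Sulfonamide

The compounds below may be only part of what the source reports. "The series", "measured", "known", "first", "only" and "open" are said of these compounds alone.

The measured compounds, in a functional assay on PC-3 cells (Homo sapiens) for inhibition, read by sulforhodamine B assay, with a stated time of 48 h; on this read-out higher numbers stand for lower toxicity in this test and lower numbers for higher toxicity in this test:
Compound 1 `C=C1CC[C@@H]2[C@](C)(COC(C)=O)[C@H](OC(C)=O)CC[C@@]2(C)[C@H]1CC(Nc1ccc(S(=O)(=O)Nc2ccc(Cl)nn2)cc1)C1=CCOC1=O` gives 15800 nM.
Compound 2 `C=C1CC[C@@H]2[C@](C)(COC(C)=O)[C@H](OC(C)=O)CC[C@@]2(C)[C@H]1CC(Nc1ccc(S(=O)(=O)Nc2cc(C)on2)cc1)C1=CCOC1=O` gives 9400 nM.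
Compound 3 `C=C1CC[C@@H]2[C@](C)(COC(C)=O)[C@H](OC(C)=O)CC[C@@]2(C)[C@H]1CC(Nc1ccc(S(=O)(=O)Nc2nccc(C)n2)cc1)C1=CCOC1=O` gives 43300 nM.

Compound 3 stands highest of the three, shown by a 2.7-fold higher number from compound 1 to compound 3 (0.44 log units; beyond the scatter) and a 4.6-fold higher number from compound 2 to compound 3 (0.66 log units; beyond the scatter), both beyond the scatter; the pair of compounds 1 and 2 sits within it, a 1.7-fold lower number from compound 1 to compound 2 (0.23 log units; within the scatter). Compound 4 `C=C1CC[C@@H]2[C@](C)(COC(C)=O)[C@H](OC(C)=O)CC[C@@]2(C)[C@H]1CC(Nc1ccc(S(=O)(=O)Nc2ncccn2)cc1)C1=CCOC1=O` differs from compound 3 by hydrogen in place of methyl on an aromatic carbon. Within the data shown here, no measured step touches this change: the three steps all exchange whole heteroaryl groups on the sulfonamide nitrogen, and none removes a single methyl. With nothing to lean on, the expected step in this assay is none beyond the scatter, a 1.2-fold lower number from compound 3 to compound 4 (0.09 log units; within the scatter). Compound 4 is therefore estimated at 35000 nM, between 14000 nM and 90000 nM.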

Compound 4, concentration lethal to 50% of the cells: 17500 nM
Beside the measured number, compound 4's estimate is 2.0-fold (0.30 log units) above it, within the range that was stated.
By their numbers in this assay, from the lowest: compounds 2, 1 and 4 (each within the scatter of the next); then compound 3.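

In this assay, removing this single methyl from the pyrimidine ring is enough to shift the number (  a 2.5-fold lower number from compound 3 to compound 4 (0.39 log units; beyond the scatter)  ), so the change at this aromatic carbon alone registers beyond the scatter. Without the methyl, the pyrimidin-2-yl compound no longer stands apart from the other two heteroaryl compounds (  a 1.9-fold higher number from compound 2 to compound 4 (0.27 log units; within the scatter)  ;  a 1.1-fold higher number from compound 1 to compound 4 (0.04 log units; within the scatter)  ), and both of these steps lie within the scatter. Nothing available explains why the methyl has this effect. The compounds shown leave open whether an ethyl, a methoxy or an amine on this carbon would raise the number as the methyl does.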